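The source may hold more compounds than are shown below. What is called first, only, known or untested is meant among the compounds shown, and "the series" means these compounds.

Series notes: compound 1 `Clc1ccc(Cn2nnc3c(Br)cccc32)cc1` and compound 2 `Brc1ccc(Cn2nnc3c(Br)cccc32)cc1` share a core, with compound 3 `Brc1cccc2c1nnn2CC1CC1` built on a different core; the difference between the two cores is not broken down here. In an ADME assay on microsomes from liver (Rattus norvegicus, strain Wistar) for metabolic stability, tested at 2.5 uM (on this read-out lower numbers stand for slow clearance and higher numbers for fast clearance), compound 1 gives 2.2 mL/min/g, compound 2 gives 2.2 mL/min/g and compound 3 gives 0.6 mL/min/g. The step of no change at the digits printed from compound 2 to compound 1 (within the scatter) follows the change (chloro in place of bromo on an aromatic carbon). Compound 3 stands lowest of the three in this assay, beyond the scatter against both compound 1 and compound 2.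

Compound 4 `Clc1cccc2c1nnn2CC1CC1` has not yet been run in this assay. Among the measured compounds shown here, it is reached from compound 3 by chloro in place of bromo on an aromatic carbon, the same kind of change as the one from compound 2 to compound 1, though not the same: there the chloro sits para to a large group, here ortho to a fused ring and meta to a fused ring, on a ring that is part of a fused or bridged system of two rings. Because the step of no change at the digits printed from compound 2 to compound 1 (within the scatter) stayed within the scatter, the step of no change at the digits printed from compound 3 to compound 4 (within the scatter) is expected to be of the same size. Compound 4 is therefore estimated at 0.6 mL/min/g in this assay, with a range from 0.3 mL/min/g to 1.2 mL/min/g.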

Compound 4, intrinsic clearance in a liver preparation (reported as CLH), per the amount of preparation that the assay uses: 0.5 mL/min/g
Estimate against measurement, compound 4: 1.2-fold (0.08 log units) above, within the range that was stated.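

In this assay the exchange of bromo for chloro gives a 1.2-fold lower number from compound 3 to compound 4 (0.08 log units; within the scatter), and set beside the earlier case the two steps do not differ: the same change on two cores in this assay, no change at the digits printed (within the scatter) from compound 2 to compound 1 and a 1.2-fold lower number (0.08 log units; within the scatter) from compound 3 to compound 4, 1.2-fold (0.08 log units) apart, within the scatter of two such steps. On these two cores, then, the change carries over with no step beyond the scatter, at both places where it is shown, so the bromo and chloro members of each pair read alike for clearance. Among the compounds shown here, this rests on only two pairs and does not show that the same would hold on a further core or at another place on the ring, nor does it explain why the two steps agree.

Still open, on these data alone, is how a group other than a halogen would read at the place of the bromo, for example a nitrile, a methoxy group, an amine or a carboxylic acid. Also open, as far as these compounds go, is which part of the difference between the core of compound 1 and the core of compound 3 goes with the lower number of compound 3.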